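The source may hold more compounds than are shown below. What is called first, only, known or untested is meant among the compounds shown, and "the series" means these compounds.

Measured so far in a functional assay on cells for agonist activity at Free fatty acid receptor 1 (Homo sapiens), read by calcium flux; on this read-out higher numbers stand for an effect only at larger amounts of compound and lower numbers for an effect already at smaller amounts:
- compound 1 `Cc1cccc(C)c1-c1cccc(COc2ccc(CC3SC(=O)NC3=O)s2)c1`: compound 1 gives 82 nM
- compound 2 `COc1ccc(F)c(-c2cccc(COc3ccc(CCC(=O)O)s3)c2)c1`: compound 2 gives 580 nM

Of the two numbers, compound 1 carries the lower one; the value of compound 2 sits well apart from it, beyond the usual scatter of this assay. The two compounds differ in more than one place, so nothing can be read from the pair about any single change; the numbers only show where each stands.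

Compound 3 `CC#CC(CC(=O)O)c1ccc(OCc2cccc(-c3c(C)cccc3C)c2)s1` is the next compound to be measured in this assay. It differs from compound 1 in one place: 1-(carboxymethyl)but-2-yn-1-yl in place of (2,4-dioxo-1,3-thiazolidin-5-yl)methyl on an aromatic carbon. The new head group keeps one hydrogen-bond donor but replaces a ring-bound head with an open chain carrying a carboxylic acid.

Among the measured compounds shown here, with no measured step of the same kind, the expectation rests on the standing of compound 1 at 82 nM and on the fact that the acid-bearing compound 2 also shows activity. A modest improvement, or a step within the scatter, is expected: a 1.6-fold lower number from compound 1 to compound 3 (0.21 log units; within the scatter). For compound 3 the estimate in this assay is 50 nM, with a range from 10 nM to 250 nM.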

Compound 3, half-maximal effective concentration: 210 nM
Beside the measured number, compound 3's estimate is 4.2-fold (0.62 log units) below it; the measured number falls inside the stated range.
By their numbers in this assay, from the lowest: compound 1; then compound 3; then compound 2.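

Among the compounds shown here, this is the first single-place comparison. In this assay, 1-(carboxymethyl)but-2-yn-1-yl in place of (2,4-dioxo-1,3-thiazolidin-5-yl)methyl, on the aromatic carbon next to the ring sulfur, gives a 2.6-fold higher number from compound 1 to compound 3 (0.41 log units; beyond the scatter), so on the core of compound 1 this position accepts an open chain with no ring and still gives a measurable effect, while the ring-bound head keeps the lower number of the pair. No supporting data bear on why the number moves, and the exchange alters the ring, the chain and the acid-bearing head all at once, so no single feature of the change can be credited with the step.

The compounds shown leave open which part of the new group accounts for the step, the carboxymethyl arm or the but-2-yn-1-yl branch. Also open, from the compounds shown here alone, is whether a tetrazole in place of the carboxylic acid, or an ethyl or cyclopropyl branch in place of the but-2-yn-1-yl branch, would bring the number back towards that of compound 1 on the same core.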